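Oxolan-2-yl for methyl on the ring-amine side chain

This account rests on a few compounds, and the source may have more. Where it says the series, first, only, none or still open, it means among the compounds named here.

Measured so far:
compound 1 `CCN1CCN(CCC(=O)Nc2nc3c(C)cccc3s2)CC1` — 1200 nM
compound 2 `Cc1cccc2sc(NC(=O)CCN3CCN(CCCN(C)C)CC3)nc12` — > 1000 nM
Not yet measured:
compound 3 `Cc1cccc2sc(NC(=O)CCN3CCN(CC4CCCO4)CC3)nc12`

Going by the values given here, in an assay on membranes from liver for displacement of a labelled ligand from Sigma intracellular receptor 2 (Rattus norvegicus), read by scintillation counting, with a stated time of 120 min (a higher number here means a weaker inhibitor, a lower number a stronger inhibitor), compound 1 gives 1200 nM, the only actual number in the set. For compound 2 this assay returns only a limit, > 1000 nM. The step that the limit leaves unreadable from compound 1 to compound 2 thus has no readable size, its end hidden by the limit of > 1000 nM in this assay, at which 1 of the 2 values shown sits.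

Compound 3 differs from compound 1 by oxolan-2-yl in place of methyl on a saturated chain carbon bound to an amine nitrogen in a ring. Among the compounds with values here, no measured step touches this position: the single step from compound 1 to compound 2 alters another carbon of the chain and, being unreadable, gives no size to borrow. The expectation therefore rests on compound 1 alone, with a step of a 1.3-fold higher number from compound 1 to compound 3 (0.10 log units; within the scatter) expected to stay within the scatter of this assay. Compound 3 is estimated at 1500 nM, in the range 500 nM to 5000 nM.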

Compound 3, inhibition constant: 5000 nM
Beside the measured number, compound 3's estimate is 3.3-fold (0.52 log units) below it, within the range that was stated.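

In this assay, the saturated chain carbon bound to an amine nitrogen in a ring now has its first readable step: oxolan-2-yl in place of methyl gives a 4.2-fold higher number from compound 1 to compound 3 (0.62 log units; beyond the scatter). This exchange brings in a five-membered non-aromatic ring and a hydrogen-bond acceptor together, so the step cannot separate the ring from its oxygen. The steps involving compound 2 cannot be read, as its value is a limit: the limit of > 1000 nM in this assay, at which 1 of the 3 values shown sits.

As far as these compounds go, it remains open whether the weaker binding follows the ring or the oxygen; cyclopentyl or methoxymethyl in place of oxolan-2-yl would separate the two. Also open, from the compounds shown here alone, is whether any group at this place can give a stronger inhibitor than compound 1, at 1200 nM, with a hydroxyl or a phenyl group as possible tests.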